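The compounds below may be only part of what the source reports. "The series", "measured", "known", "first", "only" and "open" are said of these compounds alone.

Compound 1 `COc1ccc(-c2cc(O)c3cccnc3n2)cc1`: 30200 nM
Compound 2 `Cc1cnc2nc(-c3ccc(Cl)cc3)cc(O)c2c1`: 2240 nM

In a functional assay on OVCAR-3 cells (Homo sapiens) (on this read-out lower numbers stand for stronger inhibition of growth and higher numbers for weaker inhibition of growth), compound 2 has the lower of the two numbers at 2240 nM. This puts it beyond the usual scatter from compound 1, which stands at 30200 nM. So far, compound 2 therefore shows the stronger inhibition of growth.

The next compound, not yet measured, is compound 3 `COc1ccc(-c2cc(O)c3cc(C)cnc3n2)cc1`. It has methoxy in place of chloro on an aromatic carbon, para to a large group (methoxy in place of chloro on an aromatic carbon).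

Going by the values given here, compound 1 and compound 2 differ in more than one place, so no measured step shows this swap on its own. Among the compounds with values here, the only hint is that compound 1, which also carries methoxy, gives 30200 nM. A moderate rise in the number in this assay, meaning weaker inhibition of growth and probably beyond the scatter, is therefore expected, though this is uncertain. The estimated change is a 3.1-fold higher number from compound 2 to compound 3 (0.49 log units; beyond the scatter). The expected value for compound 3 is 7000 nM. Its estimated range runs from 2000 nM to 25000 nM.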

Compound 3, concentration for 50% growth inhibition: 2950 nM
Beside the measured number, compound 3's estimate is 2.4-fold (0.38 log units) above it; the measured number falls inside the stated range.
By their numbers in this assay, from the lowest: compounds 2 and 3 (each within the scatter of the next); then compound 1.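

In this assay, methoxy in place of chloro on an aromatic carbon, para to a large group, gives a 1.3-fold higher number from compound 2 to compound 3 (0.12 log units; within the scatter) with the methyl present in both compounds, so at this position the two groups are not told apart by this read-out. The other step, methyl in place of hydrogen on an aromatic carbon, gives a 10-fold lower number from compound 1 to compound 3 (1.01 log units; beyond the scatter) and is the only single change shown here that goes beyond the scatter, pointing to stronger inhibition of growth with the small methyl group present. Nothing measured here explains either result.

On these data alone, it remains open whether methoxy and chloro would still match without the methyl, and whether other groups at the same place, such as an amine or a carboxylic acid, would also stay within the scatter. As far as these compounds go, it is also open whether a longer chain, such as ethyl or propyl in place of the methyl, would keep, add to or lose the gain seen with methyl.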